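Dimethylamino in place of pyrrolidin-1-yl on compound 3

The source may report more compounds than this note shows. Statements on the series, on what has been measured and on what is new or still open speak of the compounds shown alone.

Measured so far in a functional assay on the whole organism for antagonist activity, with Mus musculus as the target; on this read-out lower numbers stand for an effect already at smaller amounts and higher numbers for an effect only at larger amounts of compound:
- compound 1 `CC1CCC(=O)N1CC#CCN(C)C` gives > 100 mg/kg as a limit
- compound 2 `COC(=O)N(C)CC#CCN1CCCC1` gives > 10 mg/kg as a limit
- compound 3 `COC(=O)N(C)C(C)C#CCN1CCCC1` gives > 100 mg/kg as a limit

Compound 3 stands at the limit of > 100 mg/kg in this assay, at which 2 of the 3 values shown sit, and offers no number to work from. Compound 4 `COC(=O)N(C)C(C)C#CCN(C)C` differs from compound 3 by one change: dimethylamino in place of pyrrolidin-1-yl on a saturated chain carbon bound to a triple-bonded carbon and the rest of the structure stays the same. Within the data shown here, the one measured step is a step that the two limits leave unreadable from compound 2 to compound 3 and it lies at another place, so no size carries over to this change. Compound 1 also carries dimethylamino and gives > 100 mg/kg as a limit. No measured number supports a gain in this assay from this change, and none points to a loss. The expected step is a number no higher from compound 3 to compound 4 (the limit leaves the size open) and this is only an estimate with no clear direction. For compound 4 the estimate is 100 mg/kg as a rough expected value. The expected range for compound 4 runs from 30 mg/kg to 300 mg/kg and a further report as a limit is the likeliest outcome.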

Compound 4, dose for half-maximal effect: > 100 mg/kg
Compound 4 was reported as a limit (the forecaster's own chance of this, stated with the estimate: 85%); the middle value lies on the limit itself.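

Compound 3 and compound 4 both stand as limits in this assay, and no step can be read for dimethylamino in place of pyrrolidin-1-yl. The compounds shown leave open whether any of them gives a measurable dose in this assay, and whether this exchange changes it.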